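The source may report more compounds than this note shows. Statements on the series, on what has been measured and on what is new or still open speak of the compounds shown alone.

Measured compounds in an ADME assay on MT4 cells (Homo sapiens) for cytotoxicity, read by MTT assay; on this read-out lower numbers stand for higher toxicity in this test and higher numbers for lower toxicity in this test:
- compound 1 `O=C(CSc1nncnc1-c1ccccc1Cl)Nc1ccccc1Cl`: 90000 nM
- compound 2 `O=C(CSc1nncnc1-c1ccccc1Cl)Nc1ccccc1[N+](=O)[O-]`: 63000 nM
- compound 3 `O=C(CSc1nncnc1-c1ccccc1Cl)Nc1cccnc1Cl`: 167000 nM

Compound 3 gives the highest of the three numbers in this assay. The two steps that end at it are a 1.9-fold higher number from compound 1 to compound 3 (0.27 log units; within the scatter) and a 2.7-fold higher number from compound 2 to compound 3 (0.42 log units; beyond the scatter); only the second of these is beyond the scatter, so compound 3 is separated from compound 2 but not from compound 1.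

Compound 4 `O=C(CSc1nncnc1-c1ccccc1Cl)Nc1ccccc1F` is the next member. The change from compound 3 is 2-fluorophenyl in place of 2-chloropyridin-3-yl on an amide-type nitrogen. Within the data shown here, two measured steps bear on it. The step of a 1.9-fold higher number from compound 1 to compound 3 (0.27 log units; within the scatter) covers the exchange between a 2-chloropyridin-3-yl and a 2-chlorophenyl on the amide-type nitrogen and stayed within the scatter. The step of a 1.4-fold lower number from compound 1 to compound 2 (0.15 log units; within the scatter) covers a change on the phenyl ring at the same place and also stayed within the scatter. Compound 4 returns to a phenyl ring on the amide-type nitrogen, as in compound 1, so a number near that of compound 1 is expected, which means a modest move downward from compound 3 that is expected to remain within the scatter: a 1.7-fold lower number from compound 3 to compound 4 (0.22 log units; within the scatter).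

Compound 4 is therefore estimated at 100000 nM in this assay, with a range from 45000 nM to 220000 nM.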

Compound 4, half-maximal cytotoxic concentration: 98000 nM
Estimate against measurement, compound 4: 1.0-fold (0.01 log units) above; low and high end bracket the measured number.
By their numbers in this assay, from the lowest: compounds 2, 1, 4 and 3 (each within the scatter of the next, the first and the last beyond it).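

In this assay, fluoro on the aromatic carbon of the ring on the amide-type nitrogen can be read only alongside chloro and nitro, and neither exchange separates it from them: a 1.1-fold higher number from compound 1 to compound 4 (0.04 log units; within the scatter), and a 1.6-fold higher number from compound 2 to compound 4 (0.19 log units; within the scatter). Among these compounds, the 2-fluorophenyl group in place of 2-chloropyridin-3-yl also stays inside the scatter, a 1.7-fold lower number from compound 3 to compound 4 (0.23 log units; within the scatter), so compound 4 links compound 2 and compound 3, the only pair still printed as separated (a 2.7-fold higher number from compound 2 to compound 3 (0.42 log units; beyond the scatter)), through two steps that each stay within the scatter. No measurement at hand explains any of these steps.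

The compounds shown leave open whether this place tolerates groups of a different kind, such as an amine or a carboxylic acid on the ring, or a longer chain in place of the ring on the amide-type nitrogen, without moving the number beyond the scatter. They also leave open what happens in this assay when the 2-chlorophenyl group on the shared core is replaced, for example by an unsubstituted phenyl, since that part stays the same in all four compounds.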